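Replacing the nitro group of compound 3 with methyl

This account rests on a few compounds, and the source may have more. Where it says the series, first, only, none or still open, it means among the compounds named here.

Within the data shown here, compound 3 `Cc1cc(C)c2sc(NC(=O)c3ccc([N+](=O)[O-])cc3)nc2c1` is the one member of this set with a number rather than a limit: in a functional assay on SK-HEP1 cells (Homo sapiens) for antiproliferative activity, read by sulforhodamine B assay (a lower number here means a stronger inhibitor of growth, a higher number a weaker inhibitor of growth), compound 3 gives 1.74 ug/mL. Compound 1 `COc1ccc(C(=O)Nc2nc3cc(C)cc(C)c3s2)cc1` sits at the limit of the assay, giving in this assay the value > 10 ug/mL. Compound 2 `COc1ccc2sc(NC(=O)c3ccc(C)cc3)nc2c1` also returns a limit, > 10 ug/mL in this assay. Among the measured compounds shown here, the single measured step runs an at least 5.7-fold lower number from compound 1 to compound 3 (0.75 log units; beyond the scatter), and it rests on (the limit of > 10 ug/mL in this assay, at which 2 of the 3 values shown sit).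

Compound 4 `Cc1ccc(C(=O)Nc2nc3cc(C)cc(C)c3s2)cc1` differs from compound 3 by methyl in place of nitro on an aromatic carbon. The reverse of this kind of change, from a non-nitro group to nitro, is what separated compound 1 from compound 3, so the step to compound 4 is expected to run the other way, toward a weaker inhibitor of growth. Compound 2, which carries the same methyl group on the same benzamide, reached only a limit, which points the same way. Compound 4 is therefore expected to give about 15 ug/mL in this assay, in the range 4 ug/mL to 50 ug/mL, a step of an 8.6-fold higher number from compound 3 to compound 4 (0.94 log units; beyond the scatter).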

Compound 4, concentration for 50% growth inhibition: 2.17 ug/mL
Beside the measured number, compound 4's estimate is 6.9-fold (0.84 log units) above it, outside the stated range (below it).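

In this assay, methyl and nitro cannot be told apart on this aromatic carbon, para to a large group: the change gives a 1.2-fold higher number from compound 3 to compound 4 (0.10 log units; within the scatter). The nitro group is therefore not needed here for growth inhibition on the shared core, and methyl in place of methoxy gives an at least 4.6-fold lower number from compound 1 to compound 4 (0.66 log units; beyond the scatter), in the same direction as the earlier step from methoxy to nitro. Methoxy thus stands apart from the other two groups at this position, though the size of that gap is known only in part, since it starts from a limit: the limit of > 10 ug/mL in this assay, at which 2 of the 4 values shown sit.

Going by these compounds, whether an amine or a chlorine atom at this position would behave like methyl and nitro or like methoxy remains open. Compound 2 differs from compound 4 in more than one place, so the part played by the substituents on the core cannot be read from this set.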